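Benzyl for 3-chlorophenyl on the ring nitrogen

The compounds below may be only part of what the source reports. "The series", "measured", "known", "first", "only" and "open" are said of these compounds alone.

Measured in an ADME assay on Huh-7 cells (Homo sapiens) for cytotoxicity; a higher number here means that more compound is tolerated, a lower number that less compound is tolerated:
compound 1 `CCOC(=O)Cn1cc(CNCCN2CCN(C)CC2)c(-c2ccccc2C)n1`, a limit of the assay, > 20000 nM.
compound 2 `Cc1ccccc1-c1nn(-c2cccc(C(F)(F)F)c2)cc1CNCCN1CCN(C)CC1`, 18000 nM.
compound 3 `Cc1ccccc1-c1nn(-c2cccc(Cl)c2)cc1CNCCN1CCN(C)CC1`, 16000 nM.

Compound 3 and compound 2 lie within the scatter of each other, the step being a 1.1-fold lower number from compound 2 to compound 3 (0.05 log units; within the scatter) for chloro in place of trifluoromethyl. Compound 1 sits at the limit of > 20000 nM in this assay, at which 1 of the 3 values shown sits. From there, an at least 1.1-fold lower number from compound 1 to compound 2 (0.04 log units; that floor lies within the scatter) and an at least 1.2-fold lower number from compound 1 to compound 3 (0.09 log units; that floor lies within the scatter) carry only floors, both inside the scatter. Compound 4 `Cc1ccccc1-c1nn(Cc2ccccc2)cc1CNCCN1CCN(C)CC1` differs from compound 3 by benzyl in place of 3-chlorophenyl on an aromatic nitrogen. Within the data shown here, no measured step exchanges an aryl group for a benzyl group on that ring nitrogen. The steps that do change the group on the ring nitrogen all stay within the scatter. For compound 4 no movement beyond the scatter in this assay is therefore expected, that is no change at the digits printed from compound 3 to compound 4 (within the scatter). For compound 4 the estimate is 16000 nM, between 7000 nM and 32000 nM.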

Compound 4, half-maximal cytotoxic concentration: > 20000 nM
Compound 4 ended at the assay's limit; the forecaster's own chance of this, stated with the estimate: 30%; middle value at least 1.2-fold (0.09 log units) from the limit.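

In this assay compound 4 gives > 20000 nM, a limit of the assay, the second on the ring nitrogen series: the limit of > 20000 nM in this assay, at which 2 of the 4 values shown sit. Against the two aryl compounds, the result reads as an at least 1.2-fold higher number from compound 3 to compound 4 (0.09 log units; that floor lies within the scatter) and an at least 1.1-fold higher number from compound 2 to compound 4 (0.04 log units; that floor lies within the scatter); both are floors, so a benzyl group on the ring nitrogen shows no readable change from 3-chlorophenyl or 3-(trifluoromethyl)phenyl. The step between compound 1 and compound 4 cannot be read.

As far as these compounds go, how far compound 4 lies past the limit stays open. Also open, from the compounds shown here alone, is whether an amine or a carboxylic acid on the ring nitrogen would move the number beyond the scatter.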